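The compounds below may be only part of what the source reports. "The series", "measured", "known", "first", "only" and "open" are said of these compounds alone.

Compound 1 `CC(=O)c1cc(-c2ccccc2)cc2cc(-c3ccccc3)[nH]c12` is the starting point. In a functional assay on MCF7 cells (Homo sapiens) for cytotoxicity, read by MTT assay, with a stated time of 2 days (a higher number here means that more compound is tolerated, a lower number that less compound is tolerated), compound 1 gives > 100000 nM, which is a limit of the assay and not a measured number. Compound 2 `COc1ccc(-c2cc3cc(-c4ccccc4)cc(C(C)=O)c3[nH]2)cc1` carries a methoxy in place of hydrogen on an aromatic carbon. In this assay compound 2 also gives > 100000 nM, again a limit of the assay rather than a number. The step from compound 1 to compound 2 is therefore a step that the two limits leave unreadable from compound 1 to compound 2, and its size cannot be read. Among the measured compounds shown here, the whole picture so far is the limit of > 100000 nM in this assay, at which 2 of the 2 values shown sit: every value sits at the same limit, so no step has yet been seen.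

The next compound is compound 3 `CC(=O)c1cc(/C=C/c2ccc(F)cc2)cc2cc(-c3ccccc3)[nH]c12`. The change from compound 1 is 2-(4-fluorophenyl)ethenyl in place of phenyl on an aromatic carbon. For the measured compounds named here, no measured step resembles this exchange of a phenyl for a 2-(4-fluorophenyl)ethenyl, and the one step that exists is unreadable. The expectation for compound 3 therefore rests only on the limits, and compound 3 is expected to give about 100000 nM, within a range from 30000 nM to 300000 nM. This amounts to an expected a number no higher from compound 1 to compound 3 (the limit leaves the size open).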

Compound 3, concentration lethal to 50% of the cells: 18500 nM
Estimate against measurement, compound 3: 5.4-fold (0.73 log units) above; the whole stated range lies above it.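

Among the compounds shown here, the exchange of the phenyl for a 2-(4-fluorophenyl)ethenyl, on an aromatic carbon meta to the acetyl group, gives an at least 5.4-fold lower number from compound 1 to compound 3 (0.73 log units; beyond the scatter), the first step in this assay that can be read at all. A lower number here means that less compound is tolerated, so this position is one where a change of group can make the compound more harmful to the cells, something the unreadable step to compound 2 could not show. Compound 3 is the only one of the three with a measured number, and the other two stay at the limit: the limit of > 100000 nM in this assay, at which 2 of the 3 values shown sit.

This single exchange brings in a longer group, a double bond and a fluorine together, and the compounds shown cannot tell which of these matters, or how a plain 2-phenylethenyl without the fluorine or an amine at the same position would behave. As far as these compounds go, compound 1 gives > 100000 nM, which is a limit of the assay and not a number, and the full size of the step remains open.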